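A few compounds are considered here, and "the series" means these few. Any claim that something is new, unique, unknown or untested is made for them only; others in the source may bear on it.

Compound 1 `Cc1cc(C)c(S(=O)(=O)N2CCC(N3CCCCCC3)CC2)c(C)c1` gives 5.3 nM in a functional assay on DLD-1 cells (Homo sapiens) for antiproliferative activity, read by CellTiter-Glo, with a stated time of 72 h; on this read-out lower numbers stand for stronger inhibition and higher numbers for weaker inhibition. Compound 2 `Cc1cc(C)c(S(=O)(=O)N2CCC(C3OCC(C)CO3)CC2)c(C)c1` reaches only the assay limit, > 5000 nM, in this assay, and so stands at the limit of > 5000 nM in this assay, at which 1 of the 2 values shown sits. For the measured compounds named here, the only measured step bearing on the next change is an at least 940-fold higher number from compound 1 to compound 2 (2.97 log units; beyond the scatter), in which the nitrogen-containing ring of compound 1 was lost. Compound 3 `Cc1cc(C)c(S(=O)(=O)N2CCC(N3CCC(C)OC3)CC2)c(C)c1` differs from compound 2 by a group of 7 heavy atoms (5 carbon, 1 nitrogen, 1 oxygen; one six-membered non-aromatic ring with 2 hetero atoms) in place of a group of 7 heavy atoms (5 carbon, 2 oxygen; one six-membered non-aromatic ring with 2 hetero atoms), on a saturated ring carbon, which brings a nitrogen-bearing ring back to the same saturated ring carbon while retaining a ring oxygen. A step toward lower numbers is therefore expected, an at least 25-fold lower number from compound 2 to compound 3 (1.39 log units; beyond the scatter), though not necessarily a full return. Compound 3 is estimated at 200 nM, with a range of 30 nM to 2000 nM.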

Compound 3, half-maximal inhibitory concentration: 92 nM
Estimate against measurement, compound 3: 2.2-fold (0.34 log units) above; the measured number falls inside the stated range.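

Replacing the ring without nitrogen by one with a nitrogen and an oxygen at this saturated ring carbon gives an at least 54-fold lower number from compound 2 to compound 3 (1.73 log units; beyond the scatter) and so recovers activity in this assay. On these data alone, compound 2 is a limit rather than a number, so the true size of that step stays unknown: the limit of > 5000 nM in this assay, at which 1 of the 3 values shown sits. The recovery is only partial, with a 17-fold higher number from compound 1 to compound 3 (1.24 log units; beyond the scatter) showing that a ring nitrogen at this carbon does not by itself reach the level of the seven-membered ring.

Ring size and the ring oxygen remain unseparated in these compounds. A piperidine or a morpholine at this carbon would bear on that question.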